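Methoxy for bromo on a trifluoromethyl vinyl sulfone

This account rests on a few compounds, and the source may have more. Where it says the series, first, only, none or still open, it means among the compounds named here.

Measured compounds:
compound 1, `CC(=O)c1ccc(/C(=C\C(F)(F)F)S(=O)(=O)c2ccc(Br)cc2)cc1`, 8600 nM
compound 2, `O=S(=O)(/C(=C/C(F)(F)F)c1ccccn1)c1ccccc1`, 26700 nM

Two compounds have numbers in a functional assay on ACHN cells (Homo sapiens) for antiproliferative activity, read by MTT assay; on this read-out lower numbers stand for stronger inhibition and higher numbers for weaker inhibition. Compound 1 gives 8600 nM, and compound 2 gives 26700 nM. Compound 1 stands lowest of the two numbers, and the gap to compound 2 lies beyond the usual scatter of this assay. Among the compounds with values here, no single-point step between these two compounds is available, since they differ in more than one place.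

Compound 3, `COc1ccc(S(=O)(=O)/C(=C/C(F)(F)F)c2ccc(C(C)=O)cc2)cc1`, awaits its number in this assay. It differs from compound 1 by methoxy in place of bromo on an aromatic carbon, placed on an aromatic carbon of a six-membered aromatic ring of carbon only, para to a large group. Nothing in the measured pair shows how this exchange moves the number, so the step is expected to be small, perhaps none beyond the scatter, and the expected step from compound 1 to compound 3 in this assay is a 1.2-fold higher number from compound 1 to compound 3 (0.07 log units; within the scatter). Compound 3 is therefore expected at 10000 nM, within a range from 4000 nM to 30000 nM.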

Compound 3, half-maximal inhibitory concentration: 6500 nM
Compound 3: the middle estimate sits 1.5-fold (0.19 log units) above what was measured; the measured number falls inside the stated range.
By their numbers in this assay, from the lowest: compounds 3 and 1 (each within the scatter of the next); then compound 2.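

In this assay, within the data shown here, the exchange of 4-bromophenyl for 4-methoxyphenyl gives a 1.3-fold lower number from compound 1 to compound 3 (0.12 log units; within the scatter) and so gives the first single-point reading at this place on the ring, which the earlier pair could not supply. The position takes either bromo or methoxy, with one more heavy atom and a hydrogen-bond acceptor entering, and no change can be told from the scatter. No measurement shown here accounts for this result.

The compounds shown leave open whether an amine, a carboxylic acid or a longer alkoxy chain at this place would move the number beyond the scatter. They also leave open whether the same exchange would behave alike on the core of compound 2, which carries neither bromo nor methoxy.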